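Swapping a Side Chain for Phenyl on the Shared Core

The source may report more compounds than this note shows. Statements on the series, on what has been measured and on what is new or still open speak of the compounds shown alone.

Compound 1 `OCc1cc2cc(/C(=N\O)Nc3cccc(F)c3)ccc2o1`: 2400 nM
Compound 2 `O/N=C(/Nc1cccc(F)c1)c1ccc2oc(COCC3CC3)cc2c1`: 8000 nM

Among the measured compounds shown here, in an assay on tissue (HeLa cells) for inhibition of Indoleamine 2,3-dioxygenase 1 (Homo sapiens), read by spectrophotometry (on this read-out lower numbers stand for stronger inhibition and higher numbers for weaker inhibition), compound 2 gives 8000 nM, the highest of the two numbers measured so far; the nearest neighbour is compound 1, which in this assay gives 2400 nM. For the measured compounds named here, the only step measured, a 3.3-fold higher number from compound 1 to compound 2 (0.52 log units; beyond the scatter), shows that lengthening the side chain on the shared core weakened inhibition by a modest but real amount.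

Compound 3 `O/N=C(/Nc1cccc(F)c1)c1ccc2oc(-c3ccccc3)cc2c1` differs from compound 2 in one place: phenyl in place of (cyclopropylmethoxy)methyl on an aromatic carbon. Going by the values given here, no measured step covers a change of this kind, since the one step on record alters the end of the side chain rather than exchanging the whole group for an aromatic ring. The measured step therefore gives no direction for this change, and a step within the scatter is the plainest expectation, with some allowance for the side chain having already weakened inhibition once.

Compound 3 is estimated at 5000 nM in this assay, within 1200 nM to 20000 nM, meaning an expected step of a 1.6-fold lower number from compound 2 to compound 3 (0.20 log units; within the scatter).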

Compound 3, half-maximal inhibitory concentration: 10600 nM
For compound 3 the middle estimate is 2.1-fold (0.33 log units) below the measured one, within the range that was stated.
By their numbers in this assay, from the lowest: compound 1; then compounds 2 and 3 (each within the scatter of the next).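

In this assay, putting phenyl in place of (cyclopropylmethoxy)methyl on the aromatic carbon next to the ring oxygen gives a 1.3-fold higher number from compound 2 to compound 3 (0.12 log units; within the scatter), so an aromatic ring and an ether chain of the same heavy-atom count cannot be told apart at this position. Phenyl in place of the hydroxymethyl group gives a 4.4-fold higher number from compound 1 to compound 3 (0.65 log units; beyond the scatter), which means that both larger groups now sit beyond the scatter from compound 1, and the loss seen with the first change is no longer tied to a single kind of group. Nothing measured here explains why compound 1 stands apart from the other two.

Going by these compounds, what remains open is which feature of hydroxymethyl matters, and a plain methyl group or an aminomethyl group at the same place would separate the role of its oxygen from that of its small size. A carboxylic acid there, or a longer chain ending in a hydroxyl group, would show whether the end of the group or its length tracks with the number in this assay.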